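Compound 1 and a methyl on its hydroxy oxygen

This account rests on a few compounds, and the source may have more. Where it says the series, first, only, none or still open, it means among the compounds named here.

- compound 1 (`O=C(NCCCNc1cc(-c2cn(-c3ccccc3)nc2-c2cccc(O)c2)ccn1)Nc1ccc(F)cc1`) gives 3700 nM
- compound 2 (`O=C(NCCCNc1cc(-c2cn(-c3ccccc3)nc2-c2cccc(O)c2)ccn1)Nc1cccc(C(F)(F)F)c1`) gives 4240 nM

For the measured compounds named here, in a functional assay on NCI-H322M cells (Homo sapiens) for antiproliferative activity, read by sulforhodamine B assay, with a stated time of 48 h (on this read-out lower numbers stand for stronger inhibition and higher numbers for weaker inhibition), compound 1 stands level with compound 2, its only measured neighbour (a 1.1-fold higher number from compound 1 to compound 2 (0.06 log units; within the scatter)). Compound 3 (`COc1cccc(-c2nn(-c3ccccc3)cc2-c2ccnc(NCCCNC(=O)Nc3ccc(F)cc3)c2)c1`) differs from compound 1 by one change (methyl in place of hydrogen on an oxygen on an aromatic ring), hydroxy to methoxy. Going by the values given here, no measured step touches this oxygen. Among the compounds with values here, the single step available (a 1.1-fold higher number from compound 1 to compound 2 (0.06 log units; within the scatter)) lies on an amide-type nitrogen, so it is only a weak guide, and no step beyond the scatter is expected in this assay. The estimated step is small (a 1.2-fold higher number from compound 1 to compound 3 (0.09 log units; within the scatter)). For compound 3 the expected value is 4500 nM (range 1800 nM to 11000 nM).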

Compound 3, half-maximal inhibitory concentration: 9580 nM
Estimate against measurement, compound 3: 2.1-fold (0.33 log units) below; the measured number falls inside the stated range.
By their numbers in this assay, from the lowest: compounds 1 and 2 (each within the scatter of the next); then compound 3.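

For the compounds shown here, the hydroxy-to-methoxy change on the 3-hydroxyphenyl group is the first single change here to move the number beyond the scatter in this assay, with a 2.6-fold higher number from compound 1 to compound 3 (0.41 log units; beyond the scatter) as a modest loss. The earlier change on the amide-type nitrogen, a 1.1-fold higher number from compound 1 to compound 2 (0.06 log units; within the scatter) and within the scatter, showed no such response, whereas this oxygen responds to one added methyl. Nothing measured here explains this loss.

From the compounds shown here alone, what an ethoxy, an amine or a fluorine in place of the hydroxy would do remains open. Going by these compounds, it is also open whether the same methyl would cause a similar loss on compound 2.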